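This account rests on a few compounds, and the source may have more. Where it says the series, first, only, none or still open, it means among the compounds named here.

Two compounds of this series have numbers in an assay on isolated protein for inhibition of Tryptophan 2,3-dioxygenase (Homo sapiens), read by fluorescence and mass spectrometry, with stated times of 5 min and 15 min; on this read-out lower numbers stand for stronger inhibition and higher numbers for weaker inhibition. Compound 1 `Nc1oncc1-c1cccs1` gives 29 nM. Among the compounds with values here, compound 2 `Nc1oncc1-n1cccn1` gives 290 nM, the higher of the two numbers; its only measured neighbour is compound 1, whose number is lower by a margin that is beyond the scatter. Compound 3 `Cc1ccn(-c2cnoc2N)n1` has not yet been measured in this assay. It differs from compound 2 by methyl in place of hydrogen on an aromatic carbon. Within the data shown here, no step between two measured compounds resembles this change, so nothing measured fixes its size or direction. A single added methyl on an aromatic carbon is a small change, and the working expectation is a step no larger than the scatter, with no preferred direction. The estimate for compound 3 is accordingly 260 nM, inside a range from 90 nM to 750 nM. The expected step from compound 2 to compound 3 of a 1.1-fold lower number from compound 2 to compound 3 (0.05 log units; within the scatter) is taken to lie within the usual scatter.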

Compound 3, half-maximal inhibitory concentration: 1600 nM
The estimate for compound 3 lay 6.2-fold (0.79 log units) below the measured number; the measured number lies above the stated range.
By their numbers in this assay, from the lowest: compound 1; then compound 2; then compound 3.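

In this assay, methyl in place of hydrogen on an aromatic carbon of the five-membered aromatic ring with 2 nitrogen gives a 5.5-fold higher number from compound 2 to compound 3 (0.74 log units; beyond the scatter). Within the data shown here, this is the first one-place step, and it shows that this position, next to the ring nitrogen, is sensitive to substitution: a single added heavy atom moves the number beyond the scatter, and towards weaker inhibition. Nothing available accounts for the size or direction of this step.

A single step at a single place cannot show whether the higher number is specific to methyl or would come with any group other than hydrogen at this carbon. On these data alone, it also remains open whether an amine, a hydroxyl or a longer chain here, or methyl on the other ring carbons, would give a step of similar size.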